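The compounds below may be only part of what the source reports. "The series", "measured", "known", "first", "only" and "open" are said of these compounds alone.

Working notes on the series. In a functional assay on HT-29 cells (Homo sapiens) for inhibition, read by MTT assay, with a stated time of 72 h (a higher number here means a weaker inhibitor, a lower number a stronger inhibitor), compound 1 (`COc1cccc(/C=C/C(=O)Nc2cc(OC)c(OC)c(OC)c2)c1`) gives 44100 nM, compound 2 (`COc1cc(NC(=O)/C=C/c2cccc(OCc3ccccc3)c2)cc(OC)c1OC`) gives 3600 nM and compound 3 (`C=C(Br)C(=O)Nc1cccc(/C=C/C(=O)Nc2cccc(F)c2)c1`) gives 4600 nM. Compound 3 is level with compound 2 within the scatter and stands well under compound 1. Compound 4 (`C=C(Br)C(=O)Nc1cccc(/C=C/C(=O)Nc2ccc(Cl)cc2)c1`) follows from compound 3 with 4-chlorophenyl in place of 3-fluorophenyl on an amide-type nitrogen. Among the measured compounds shown here, the only measured step, a 12-fold lower number from compound 1 to compound 2 (1.09 log units; beyond the scatter), is large but lies at a saturated chain carbon bound to an oxygen on an aromatic ring, so it does not bear on this exchange. For the measured compounds named here, no measured step covers the group on that nitrogen, so no change beyond the scatter is expected in this assay. The expected step is a 1.2-fold lower number from compound 3 to compound 4 (0.06 log units; within the scatter). Compound 4 is estimated at 4000 nM, with an expected range of 1500 nM to 11000 nM.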

Compound 4, half-maximal inhibitory concentration: 7900 nM
Compound 4: the middle estimate sits 2.0-fold (0.30 log units) below what was measured; the range from low to high includes it.
By their numbers in this assay, from the lowest: compounds 2, 3 and 4 (each within the scatter of the next, the first and the last beyond it); then compound 1.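

Among the compounds shown here, at the amide-type nitrogen, this assay reads 4-chlorophenyl in place of 3-fluorophenyl as a 1.7-fold higher number from compound 3 to compound 4 (0.23 log units; within the scatter), the first measured step at this position, and compound 3 and compound 4 stand level. This exchange of one halogen-bearing phenyl for another therefore gives no change beyond the scatter. No supporting measurement accounts for the result.

The step alters the halogen and its ring location together and does not separate the two. Going by these compounds, whether a carboxylic acid or an amine on that phenyl would shift the number beyond the scatter stays open.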